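A few compounds are considered here, and "the series" means these few. Any claim that something is new, unique, unknown or untested is made for them only; others in the source may bear on it.

Measured compounds in a functional assay on MCF7 cells (Homo sapiens) for cytotoxicity, read by sulforhodamine B assay, with a stated time of 72 h; on this read-out higher numbers stand for weaker inhibition and lower numbers for stronger inhibition:

compound 1 `Cc1c(-c2csc(NC(=S)Nc3ccccc3)n2)c(=O)n(-c2ccccc2)n1C` gives 10100 nM
compound 2 `Cc1c(-c2csc(/N=c3\sc(-c4ccccc4)nn3-c3ccccc3)n2)c(=O)n(-c2ccccc2)n1C` returns only a limit of the assay, > 100000 nM
compound 3 `CC(=O)c1nn(-c2ccccc2)/c(=N/c2nc(-c3c(C)n(C)n(-c4ccccc4)c3=O)cs2)s1` returns only a limit of the assay, > 100000 nM

Going by the values given here, compound 3 therefore has no number in this assay, only a limit; compound 2 sits at the same kind of limit, so the sole one-point step in the set, a step that the two limits leave unreadable from compound 2 to compound 3, cannot be read in size or direction. Among the compounds with values here, the one numbered value, that of compound 1, lies well inside the range and belongs to a compound whose core differs from compounds 2 and 3 in more than one place, so no step from it is counted. The weight of the evidence is that (the limit of > 100000 nM in this assay, at which 2 of the 3 values shown sit).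

Compound 4 `CC(=O)c1nn(-c2ccc(Cl)cc2)/c(=N/c2nc(-c3c(C)n(C)n(-c4ccccc4)c3=O)cs2)s1` differs from compound 3 only in that (chloro in place of hydrogen on an aromatic carbon). Within the data shown here, no measured step touches a change of this kind, and the parent value is itself a limit. Compound 4 is therefore expected to remain at or near the same limit in this assay, and the step of a number no higher from compound 3 to compound 4 (the limit leaves the size open) is estimated as none beyond the scatter. The estimate for compound 4 is 100000 nM, with a range from 30000 nM to 300000 nM, and a limit rather than a number is the more probable outcome.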

Compound 4, half-maximal inhibitory concentration: > 100000 nM
Compound 4: a limit, no number; the forecaster's own chance of this, stated with the estimate: 75%; the middle value lies on the limit itself.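

Compound 4 gives > 100000 nM in this assay, a limit and not a number; with compound 3 also at a limit, no new step can be read between compound 3 and compound 4. The compounds shown leave open whether phenyl to 4-chlorophenyl changes potency at all, with the series resting on this: the limit of > 100000 nM in this assay, at which 3 of the 4 values shown sit.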